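Furan-3-yl in place of furan-2-yl on compound 2

The source may hold more compounds than are shown below. What is called first, only, known or untested is meant among the compounds shown, and "the series" means these compounds.

Measured compounds in a functional assay on CCRF-CEM cells (Homo sapiens), read by MTT assay, with a stated time of 72 h; on this read-out lower numbers stand for stronger inhibition and higher numbers for weaker inhibition:
compound 1 `COc1ncnc2c1c(-c1ccco1)cn2[C@@H]1O[C@H](CO)[C@@H](O)[C@H]1O` gives 20 nM.
compound 2 `Nc1nc2c(c(-c3ccco3)cn2[C@@H]2O[C@H](CO)[C@@H](O)[C@H]2O)c(=O)[nH]1` gives > 20000 nM, a limit of the assay and not a number.
compound 3 `O=c1[nH]cnc2c1c(-c1ccco1)cn2[C@@H]1O[C@H](CO)[C@@H](O)[C@H]1O` gives > 20000 nM, a limit of the assay and not a number.

Compound 2 stands at the upper limit: the limit of > 20000 nM in this assay, at which 2 of the 3 values shown sit. Going by the values given here, no number of its own is therefore available for compound 2, and the only numbered value in the set belongs to compound 1. Among the compounds with values here, the single measured step, a step that the two limits leave unreadable from compound 2 to compound 3, joins two limits and its size cannot be read. Within the data shown here, compound 1 differs from compound 2 in more than one place, so no step between them is drawn; their values show only that compound 1 gives a number while compound 2 does not.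

Compound 4 `Nc1nc2c(c(-c3ccoc3)cn2[C@@H]2O[C@H](CO)[C@@H](O)[C@H]2O)c(=O)[nH]1` is the next member. It differs from compound 2 by furan-3-yl in place of furan-2-yl on an aromatic carbon. Among the measured compounds shown here, none of the measured steps touches the furan position, and the one measured step is itself unreadable, so nothing in the data bears directly on this change. With compound 2 at the limit and the same atoms merely joined differently, compound 4 is expected to remain at the limit as well; the step of a number no higher from compound 2 to compound 4 (the limit leaves the size open) is estimated to be none beyond the scatter. The estimate for compound 4 is 20000 nM, with a range from 5000 nM to 20000 nM.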

Compound 4, half-maximal inhibitory concentration: 17900 nM
Compound 4: the middle estimate sits 1.1-fold (0.05 log units) above what was measured; the measured number falls inside the stated range.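

In this assay, going by these compounds alone, the change to furan-3-yl gives the first number with a value of its own for this amino-bearing series, as compound 4 gives 17900 nM. On these data alone, the move of the attachment point within the furan ring is recorded as an at least 1.1-fold lower number from compound 2 to compound 4 (0.04 log units; that floor lies within the scatter), so no shift beyond the usual scatter is established for this change, though the true size of the step remains open. Compound 2 remains a limit and not a number: the limit of > 20000 nM in this assay, at which 2 of the 4 values shown sit.

The step from compound 2 to compound 3 joins two limits and cannot be read, so the part played by the amino group on the aromatic carbon remains undefined at this position. Also open, as far as these compounds go, is whether furan-3-yl would be tolerated on the core of compound 1, which gives 20 nM, and whether a thiophene ring or a phenyl ring at the same place would give a number clearly apart from that of compound 4.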